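From Acetyl to (4-Cyanophenyl)sulfonyl on the Ring Nitrogen

The source may hold more compounds than are shown below. What is called first, only, known or untested is meant among the compounds shown, and "the series" means these compounds.

Of the compounds shown here, three sharing one core have been measured in a functional assay on NCI-H1975 cells (Homo sapiens) for inhibition, read by sulforhodamine B assay, tested at 10 uM; on this read-out higher numbers stand for more inhibition at the one concentration tested (going by the name of the read-out) and lower numbers for less inhibition. Compound 1 `CN1CCN(c2ccc(C3=NNC(c4ccc(N(C)C)cc4)C3)cc2)CC1` bears a hydrogen on the amine nitrogen in the ring, and in this assay compound 1 gives 2.4%. Compound 2 `CC(=O)N1N=C(c2ccc(N3CCN(C)CC3)cc2)CC1c1ccc(N(C)C)cc1` bears an acetyl there, and in this assay compound 2 gives -1.9%. Compound 3 `CN1CCN(c2ccc(C3=NN(C(=O)CCCl)C(c4ccc(N(C)C)cc4)C3)cc2)CC1` bears a (2-chloroethyl)carbonyl, and in this assay compound 3 gives -0.2%. Compound 2 holds the lowest of the three numbers, but its distances to the others lie within the scatter, as shown by a number 4.3 percentage points lower from compound 1 to compound 2 (within the scatter) and a number 1.7 percentage points higher from compound 2 to compound 3 (within the scatter), and likewise a number 2.6 percentage points lower from compound 1 to compound 3 (within the scatter).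

Compound 4 `CN1CCN(c2ccc(C3=NN(S(=O)(=O)c4ccc(C#N)cc4)C(c4ccc(N(C)C)cc4)C3)cc2)CC1` has not been measured. Its change from compound 2 is (4-cyanophenyl)sulfonyl in place of acetyl on an amine nitrogen in a ring. For the measured compounds named here, the steps that bear on it are the two that substitute the same ring nitrogen, a number 4.3 percentage points lower from compound 1 to compound 2 (within the scatter) and a number 2.6 percentage points lower from compound 1 to compound 3 (within the scatter), and the one that lengthens the acyl group, a number 1.7 percentage points higher from compound 2 to compound 3 (within the scatter); all three are within the scatter. Going by the values given here, no measured step introduces a sulfonyl or an aromatic ring at this position, so the precedent is thin. On that basis the expected step is a number 3.9 percentage points higher from compound 2 to compound 4 (within the scatter), none beyond the scatter. The estimate for compound 4 in this assay is 2%, with a range from -12% to 18%.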

Compound 4, a percentage reported as inhibition, at one concentration (the size of the read-out at that concentration, not a potency): 100%
Estimate against measurement, compound 4: 98 percentage points below; measured number above the stated range.
By their numbers in this assay, from the lowest: compounds 2, 3 and 1 (each within the scatter of the next); then compound 4.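

In this assay the ring nitrogen had shown no step beyond the scatter with hydrogen, acetyl or (2-chloroethyl)carbonyl, yet the same position now gives a number 101.9 percentage points higher from compound 2 to compound 4 (beyond the scatter) and a number 100.2 percentage points higher from compound 3 to compound 4 (beyond the scatter) as well as a number 97.6 percentage points higher from compound 1 to compound 4 (beyond the scatter) with (4-cyanophenyl)sulfonyl, so what this nitrogen carries can matter a great deal in this read-out. The change is not a single feature: 3 heavy atoms of acetyl leave and 11 heavy atoms enter, bringing a sulfonyl, one six-membered aromatic ring of carbon only and a nitrile together, and these compounds cannot assign the large steps to any one of those parts. Nothing measured here accounts for the size of these steps.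

Left open is whether a methylsulfonyl, with no aromatic ring, or a plain phenylsulfonyl, without the nitrile, would stand near compound 4 or near the other three compounds, and whether a 4-cyanobenzoyl would do so with a carbonyl in place of the sulfonyl. Also open, on these data alone, is how compound 4 behaves at lower concentrations, as this assay reports a single concentration and not a potency.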